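The compounds below may be only part of what the source reports. "The series", "measured", "known", "first", "only" and "open" are said of these compounds alone.

Measured compounds:
compound 1 `CC(C)[C@H](NC(=O)CCN(C)C)c1cccc(F)c1N1CCN(C(=O)[C@@H]2CN(C(C)C)C[C@H]2c2ccc(C(F)(F)F)c(F)c2)CC1`, 51 nM in an assay on HEK293 cells for displacement of a labelled ligand from Melanocortin receptor 4 (Homo sapiens); a higher number here means a weaker inhibitor, a lower number a stronger inhibitor
compound 2 `Cc1ccc(N2CCN(C(=O)[C@@H]3CN(C4CCOCC4)C[C@H]3c3ccc(Cl)cc3)CC2)c([C@@H](NC(=O)[C@@H](C)N)C(C)C)c1`, 7.3 nM
compound 3 `Cc1ccc(N2CCN(C(=O)[C@@H]3CN(C4CCOCC4)C[C@H]3c3ccc(Cl)cc3)CC2)c([C@@H](NC(=O)CCN)C(C)C)c1`, 2.2 nM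

Compound 1 gives the highest number of the three, and its nearest neighbour on the numbers is compound 2. For the measured compounds named here, the only step between measured compounds, a 3.3-fold lower number from compound 2 to compound 3 (0.52 log units; beyond the scatter), concerns the amide end of the molecule and not the aryl group on the five-membered ring.

Compound 4 `CC(C)[C@H](NC(=O)CCN(C)C)c1cccc(F)c1N1CCN(C(=O)[C@@H]2CN(C(C)C)C[C@H]2c2ccc(F)c(Cl)c2)CC1` differs from compound 1 in a single place: 3-chloro-4-fluorophenyl in place of 3-fluoro-4-(trifluoromethyl)phenyl on a saturated ring carbon. Going by the values given here, no measured pair speaks to this change; compounds 2 and 3 carry a different aryl group but also differ from compound 1 elsewhere, so their values cannot be read onto this step. The expectation is therefore a step of about a 1.1-fold lower number from compound 1 to compound 4 (0.05 log units; within the scatter), within the scatter. Compound 4 is estimated at 45 nM, between 18 nM and 120 nM.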

Compound 4, inhibition constant: 260 nM
Compound 4: middle estimate off by 5.8-fold (0.76 log units), on the low side; measured number outside the range, above it.
By their numbers in this assay, from the lowest: compound 3; then compound 2; then compound 1; then compound 4.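

In this assay, for the compounds shown here, this is the first single-place reading at the aryl group on the saturated ring carbon: 3-chloro-4-fluorophenyl in place of 3-fluoro-4-(trifluoromethyl)phenyl gives a 5.1-fold higher number from compound 1 to compound 4 (0.71 log units; beyond the scatter). This position therefore responds to the aryl substitution, and of these two groups 3-fluoro-4-(trifluoromethyl)phenyl gives the stronger inhibitor on this core. Nothing at hand gives a reason for this step.

Both aryl substituents change at once, so the step cannot be assigned to either; a 3,4-dichlorophenyl or a 4-(trifluoromethyl)phenyl group on the same core would separate them. From the compounds shown here alone, whether the step carries over to the primary amine amide end of compound 3 remains open.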